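The source may report more compounds than this note shows. Statements on the series, on what has been measured and on what is new or still open speak of the compounds shown alone.

Measured compounds:
- compound 1, `O=C(NCCCCc1ccccc1)c1cccc(C2SCC(=O)N2c2cnccn2)c1`: > 1000 nM
- compound 2, `O=C(NCCCCc1ccccc1)c1cccc(C2SCC(=O)N2c2ccccn2)c1`: 19.7 nM

In a functional assay on HOS-TE85 cells (Homo sapiens) for inhibition, read by CCK-8 assay, with a stated time of 72 h (a lower number here means a stronger inhibitor, a higher number a weaker inhibitor), compound 1 gives > 1000 nM, which is a limit of the assay and not a number (the limit of > 1000 nM in this assay, at which 1 of the 2 values shown sits). For the measured compounds named here, compound 2 gives 19.7 nM, the only number among the two values shown. The step from compound 1 to compound 2 is an at least 50-fold lower number from compound 1 to compound 2 (1.70 log units; beyond the scatter).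

Compound 3, `COc1ccc(N2C(=O)CSC2c2cccc(C(=O)NCCCCc3ccccc3)c2)c(OC)c1`, is not yet measured. It differs from compound 2 in one place: 2,4-dimethoxyphenyl in place of pyridin-2-yl on an amide-type nitrogen in a ring. The change sits at the same amide-type nitrogen in the ring where the measured step of an at least 50-fold lower number from compound 1 to compound 2 (1.70 log units; beyond the scatter) was taken, so that step is the only one that bears on it. It shows that this position can move the readout by a large amount, but the groups compared there were two nitrogen-containing six-membered aromatic rings, and a 2,4-dimethoxyphenyl is a different kind of replacement, so its direction cannot be read from that step alone. A step beyond the scatter is expected, more likely toward a higher number than toward a lower one; the estimated step is a 10-fold higher number from compound 2 to compound 3 (1.01 log units; beyond the scatter), and compound 3 is expected to give 200 nM, in the range 30 nM to 1500 nM.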

Compound 3, half-maximal inhibitory concentration: 90.4 nM
Beside the measured number, compound 3's estimate is 2.2-fold (0.34 log units) above it; measured number inside the range.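

Compound 3 shows that the group on the amide-type nitrogen in the ring need not carry a ring hetero atom: in this assay, 2,4-dimethoxyphenyl in place of pyridin-2-yl gives a 4.6-fold higher number from compound 2 to compound 3 (0.66 log units; beyond the scatter). Measured against pyrazin-2-yl, the same group gives an at least 11-fold lower number from compound 1 to compound 3 (1.04 log units; beyond the scatter), so the loss seen with pyrazin-2-yl is not shared by every replacement of pyridin-2-yl among the three compounds. The reading for compound 1 is a limit of the assay and not a number, so this second step has no exact size: the limit of > 1000 nM in this assay, at which 1 of the 3 values shown sits.

The 2,4-dimethoxyphenyl group enters as a single change, which leaves open what each methoxy group contributes, and a plain phenyl or a phenyl with a single methoxy group would separate the two. Also open, from the compounds shown here alone, is whether a larger group at this nitrogen, such as a naphthyl, or a phenyl carrying an amine or a carboxylic acid, would keep the reading near those of compound 2 and compound 3.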